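This account rests on a few compounds, and the source may have more. Where it says the series, first, only, none or still open, it means among the compounds named here.

Notes on the series. Compound 1 `COc1cc(-c2ccnc3cc(-c4ccccc4)nn23)cc(OC)c1OC` is the parent: in a functional assay on HeLa cells (Homo sapiens) for inhibition, read by CCK-8 assay, with a stated time of 48 h (on this read-out lower numbers stand for stronger inhibition and higher numbers for weaker inhibition), compound 1 gives 458 nM, the second highest of the three numbers at hand. Compound 2 `COc1cc(-c2ccnc3cc(-c4ccc(N(C)C)cc4)nn23)cc(OC)c1OC` carries dimethylamino in place of hydrogen on an aromatic carbon and gives 378 nM; the step is a 1.2-fold lower number from compound 1 to compound 2 (0.08 log units; within the scatter). Compound 3 `COc1cc(-c2ccnc3cc(-c4cccc(C)c4)nn23)cc(OC)c1OC` carries methyl in place of hydrogen on an aromatic carbon and gives 4230 nM; here a 9.2-fold higher number from compound 1 to compound 3 (0.97 log units; beyond the scatter), and from compound 2 the gap is an 11-fold higher number from compound 2 to compound 3 (1.05 log units; beyond the scatter). Compound 4 `COc1ccc(-c2cc3nccc(-c4cc(OC)c(OC)c(OC)c4)n3n2)cc1F` is not yet measured; it differs from compound 1 by 3-fluoro-4-methoxyphenyl in place of phenyl on an aromatic carbon. Both earlier steps bear on it: one ring substituent left the number essentially where it was, the other raised it substantially, and the 3-fluoro-4-methoxyphenyl group combines fluorine and methoxy on that ring. A modest rise, or none beyond the scatter, is therefore expected in this assay; the expected step is a 2.0-fold higher number from compound 1 to compound 4 (0.29 log units; within the scatter). Compound 4 is estimated at 900 nM, with a range from 250 nM to 3500 nM.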

Compound 4, half-maximal inhibitory concentration: 236 nM
Estimate against measurement, compound 4: 3.8-fold (0.58 log units) above, and the stated range ends above it.
By their numbers in this assay, from the lowest: compounds 4, 2 and 1 (each within the scatter of the next); then compound 3.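

In this assay, 3-fluoro-4-methoxyphenyl on this aromatic carbon leaves the number within the scatter of both earlier active compounds, with a 1.9-fold lower number from compound 1 to compound 4 (0.29 log units; within the scatter) and a 1.6-fold lower number from compound 2 to compound 4 (0.20 log units; within the scatter) as the steps, so this position accepts a phenyl ring bearing both fluorine and methoxy. The sharp rise seen with 3-methylphenyl therefore does not extend to every substituted phenyl: an 18-fold lower number from compound 3 to compound 4 (1.25 log units; beyond the scatter) is a large step, and compound 3 alone stands apart among the four compounds. No measurement at hand accounts for the gap between these two groups.

The separate contributions of fluorine and methoxy remain open, as 3-fluorophenyl and 4-methoxyphenyl are not among the compounds shown. Also open, from the compounds shown here alone, is how this position responds to a carboxylic acid or a primary amine on the phenyl ring.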